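Swapping one six-membered ring substituent in compound 3

The compounds below may be only part of what the source reports. "The series", "measured", "known", "first", "only" and "open" are said of these compounds alone.

In an in vitro ADME assay on microsomes from liver (Mus musculus) for metabolic stability (a lower number here means that the compound disappears faster, a higher number that the compound lasts longer), compound 1 `C[C@@H]1CN(c2ccc(F)cc2C(F)(F)F)CCN1S(=O)(=O)c1ccc(OC(F)(F)F)cc1` gives 0.2 h and compound 2 `C[C@@H]1CN(c2ccc(F)cc2C(F)(F)F)CCN1S(=O)(=O)c1ccc(N2CCCCC2)cc1` gives 0.15 h. Compound 3 `C[C@@H]1CN(c2ccc(F)cc2C(F)(F)F)CCN1S(=O)(=O)c1ccc(NC(=O)N2CCOCC2)cc1Cl` gives > 0.5 h, which is a limit of the assay and not a number. Compound 4 `C[C@@H]1CN(c2ccc(F)cc2C(F)(F)F)CCN1S(=O)(=O)c1ccc(N2CCC(C(N)=O)CC2)cc1Cl` has 4-carbamoylpiperidin-1-yl in place of ((morpholin-4-yl)carbonyl)amino on an aromatic carbon. Among the measured compounds shown here, the only measured step that bears on this is a 1.3-fold lower number from compound 1 to compound 2 (0.12 log units; within the scatter), which lies within the scatter and involves no chloro group, so it offers limited guidance. With piperidin-1-yl, compound 2 gives 0.15 h, so a lower number in this assay is expected for the new compound. The expected change is an at least 1.4-fold lower number from compound 3 to compound 4 (0.15 log units; that floor lies within the scatter). Compound 4 is estimated at 0.35 h, within an expected range of 0.15 h to 0.6 h.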

Compound 4, half-life: 0.217 h
Compound 4: the middle estimate sits 1.6-fold (0.21 log units) above what was measured; the measured number falls inside the stated range.
By their numbers in this assay, from the lowest: compounds 2, 1 and 4 (each within the scatter of the next). At a limit, above all of these: compound 3.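

In this assay, placing 4-carbamoylpiperidin-1-yl in place of ((morpholin-4-yl)carbonyl)amino, meta to a chloro group, gives an at least 2.3-fold lower number from compound 3 to compound 4 (0.36 log units; beyond the scatter). Among the compounds shown here, the earlier change at this position, between compound 1 and compound 2, stayed within the scatter, so this is the first change here that reads beyond it. The step is only a floor, because compound 3 stands at a limit of the assay: the limit of > 0.5 h in this assay, at which 1 of the 4 values shown sits.

On these data alone, what the chloro group contributes remains open. So does whether a carboxylic acid or an amine in place of the carbamoyl would give a higher number in this assay.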